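A few compounds are considered here, and "the series" means these few. Any claim that something is new, unique, unknown or untested is made for them only; others in the source may bear on it.

Working notes on the series. Two compounds have numbers in a functional assay on COLO 205 cells (Homo sapiens) for inhibition, read by sulforhodamine B assay, with a stated time of 48 h; on this read-out lower numbers stand for stronger inhibition of growth and higher numbers for weaker inhibition of growth. Compound 1, `O=C(Nc1cccc(-n2cc(-c3ccncc3)c(-c3ccc(Cl)c(O)c3)n2)c1)Nc1ccc(Cl)c(Cl)c1`, gives in this assay a value of 9490 nM. Compound 2, `COc1cc(-c2nn(-c3cccc(NC(=O)c4ccc(Cl)c(C(F)(F)F)c4)c3)cc2-c2ccncc2)ccc1Cl`, gives in this assay a value of 23300 nM, the highest of the two numbers; its nearest neighbour is compound 1, whose number is lower by a gap beyond the usual scatter. Among the compounds with values here, no pair of measured compounds differs in a single place, so no measured step is available to lean on.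

Compound 3, `COc1cc(-c2nn(-c3cccc(NC(=O)c4cccc(C(F)(F)F)c4)c3)cc2-c2ccncc2)ccc1Cl`, is not yet measured. It differs from compound 2 as follows: hydrogen in place of chloro on an aromatic carbon. The change sits on an aromatic carbon of a six-membered aromatic ring of carbon only, ortho to a trifluoromethyl group and para to a large group; one bond further out it reads 4-chloro-3-(trifluoromethyl)phenyl to 3-(trifluoromethyl)phenyl.

With no measured step of this kind in the series, the expected step from compound 2 to compound 3 in this assay is a 1.3-fold higher number from compound 2 to compound 3 (0.11 log units; within the scatter), small and likely within the scatter, if anything towards a higher number. For compound 3 the estimate in this assay is 30000 nM, with a range from 10000 nM to 90000 nM.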

Compound 3, concentration for total growth inhibition: 5170 nM
Compound 3: the middle estimate sits 5.8-fold (0.76 log units) above what was measured; measured number outside the range, below it.
By their numbers in this assay, from the lowest: compounds 3 and 1 (each within the scatter of the next); then compound 2.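

In this assay, within the data shown here, the change from 4-chloro-3-(trifluoromethyl)phenyl to 3-(trifluoromethyl)phenyl gives a 4.5-fold lower number from compound 2 to compound 3 (0.65 log units; beyond the scatter), the first single-place step and one that lies beyond the scatter. At this position, ortho to a trifluoromethyl group and para to a large group, the chloro is therefore not needed for inhibition of growth in this pair, and hydrogen gives the stronger inhibition. No measurement at hand bears on why the step occurs.

As far as these compounds go, it remains open whether a methyl group or an amine at this position would match hydrogen or fall back towards chloro. Among these compounds, it also remains open whether the step holds when the trifluoromethyl group is replaced, since only this one pair speaks for the position.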